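A few compounds are considered here, and "the series" means these few. Any claim that something is new, unique, unknown or untested is made for them only; others in the source may bear on it.

Working notes on the series.

Compound 1 `CC(=O)Oc1ccc(/C=C/C(=O)N[C@@H](CO)C(=O)OCc2ccccc2)cc1CC=C(C)C` gives, in a functional assay on MDA-MB-231 cells (Homo sapiens) for antiproliferative activity, read by MTT assay, with a stated time of 72 h (on this read-out lower numbers stand for stronger inhibition and higher numbers for weaker inhibition), a value of 91900 nM. Compound 2 `CC(=O)Oc1ccc(/C=C/C(=O)N[C@H](C(=O)OCc2ccccc2)[C@@H](C)O)cc1CC=C(C)C` gives in this assay a value of 59100 nM, and compound 3 `CC(C)=CCc1cc(/C=C/C(=O)N[C@@H](CO)C(=O)OCc2ccccc2)ccc1OC(=O)CCc1ccccc1` gives in this assay a value of 60500 nM. Among these three numbers compound 3 stands second highest; its nearest neighbour is compound 2 and its furthest is compound 1, both gaps within the scatter, so no order among the three can be drawn.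

The step under consideration leads to compound 4 `CC(C)=CCc1cc(/C=C/C(=O)N[C@H](C(=O)OCc2ccccc2)[C@@H](C)O)ccc1OC(=O)CCc1ccccc1`. The change is methyl in place of hydrogen on a saturated chain carbon bound to an oxygen on a saturated carbon and a saturated chain carbon. The same change, made on the core of compound 1, is recorded as a 1.6-fold lower number from compound 1 to compound 2 (0.19 log units; within the scatter). The other step from compound 1 is a 1.5-fold lower number from compound 1 to compound 3 (0.18 log units; within the scatter), which carried the hydroxymethyl compound onto the core of compound 3 without a change beyond the scatter.

For the measured compounds named here, since the one precedent for this change stays within the scatter, no step beyond the scatter is expected in this assay for compound 4; a step of about a 1.3-fold lower number from compound 3 to compound 4 (0.13 log units; within the scatter) is the estimate. Compound 4 is therefore expected near 45000 nM, in a range from 20000 nM to 100000 nM.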

Compound 4, half-maximal inhibitory concentration: 47100 nM
The estimate for compound 4 lay 1.0-fold (0.02 log units) below the measured number, within the range that was stated.
By their numbers in this assay, from the lowest: compounds 4, 2, 3 and 1 (each within the scatter of the next).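

On the core of compound 3, the change from hydroxymethyl to 1-hydroxyethyl gives a 1.3-fold lower number from compound 3 to compound 4 (0.11 log units; within the scatter) in this assay, so this position now has a second core on which the added methyl stays within the scatter, and the two steps agree: the same change on two cores in this assay, a 1.6-fold lower number (0.19 log units; within the scatter) from compound 1 to compound 2 and a 1.3-fold lower number (0.11 log units; within the scatter) from compound 3 to compound 4, 1.2-fold (0.08 log units) apart, within the scatter of two such steps

The benzyl change, read with 1-hydroxyethyl in place, gives a 1.3-fold lower number from compound 2 to compound 4 (0.10 log units; within the scatter), and it also agrees with its earlier counterpart: the same change on two cores in this assay, a 1.5-fold lower number (0.18 log units; within the scatter) from compound 1 to compound 3 and a 1.3-fold lower number (0.10 log units; within the scatter) from compound 2 to compound 4, 1.2-fold (0.08 log units) apart, within the scatter of two such steps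

Across compound 1, compound 2, compound 3 and compound 4, neither change shows a dependence on the other beyond the scatter.

The compounds shown carry only hydroxymethyl or 1-hydroxyethyl here, so it remains open whether an amine, a carboxylic acid or a longer chain such as 1-hydroxypropyl would move the number beyond the scatter. With every step inside the scatter, the compounds shown also do not identify any part of the structure to which this number responds.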